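A few compounds are considered here, and "the series" means these few. Any claim that something is new, unique, unknown or untested is made for them only; others in the source may bear on it.

Among the measured compounds shown here, compound 3 `CCSC(=O)C1=C(C)NC(=O)NC1c1cccs1` carries the ethylsulfanyl group and gives 1% in an assay on membranes from HEK293 cells for displacement of a labelled ligand from adenosine receptor A2b (Homo sapiens), read by scintillation counting, with a stated time of 30 min, tested at 1 uM (on this read-out lower numbers stand for less inhibition and higher numbers for more inhibition at the one concentration tested (going by the name of the read-out)), the lowest of the three numbers measured so far. Compound 1 `COC(=O)C1=C(C)NC(=O)NC1c1cccs1` gives 19% and compound 2 `CC1=C(C(=O)OC(C)(C)C)C(c2cccs2)NC(=O)N1` gives 38% in this assay; both stand beyond the scatter above compound 3. Compound 4 `CCC(C)OC(=O)C1=C(C)NC(=O)NC1c1cccs1` is not yet measured. It differs from compound 3 in one place: sec-butoxy in place of ethylsulfanyl on a carbonyl carbon. For the measured compounds named here, two measured steps bear on this change. Putting ethylsulfanyl in place of methoxy gave a number 18 percentage points lower from compound 1 to compound 3 (beyond the scatter), and putting ethylsulfanyl in place of tert-butoxy gave a number 37 percentage points lower from compound 2 to compound 3 (beyond the scatter); read in reverse, both say that restoring an alkoxy group in place of ethylsulfanyl raises the number. The step of a number 19 percentage points higher from compound 1 to compound 2 (beyond the scatter) further suggests that a larger alkyl on the oxygen lifts the read-out, although that rests on two compounds only. Sec-butoxy is neither as small as methoxy nor as large as tert-butoxy, so a rise of a size between those two reversed steps is expected, namely a number 29 percentage points higher from compound 3 to compound 4 (beyond the scatter) in this assay. Compound 4 is therefore estimated at 30% in this assay, with a range from 12% to 48%.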

Compound 4, a percentage reported as inhibition, at one concentration (the size of the read-out at that concentration, not a potency): 7%
Compound 4: the middle estimate sits 23 percentage points above what was measured; the whole stated range lies above it.
By their numbers in this assay, from the lowest: compounds 3 and 4 (each within the scatter of the next); then compound 1; then compound 2.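

In this assay, sec-butoxy in place of ethylsulfanyl on the carbonyl carbon gives a number 6 percentage points higher from compound 3 to compound 4 (within the scatter) and so does not separate the two groups, which shows that an alkoxy group at this place does not by itself restore the higher numbers of compound 1 and compound 2. With the oxygen kept, sec-butyl in place of tert-butyl gives a number 31 percentage points lower from compound 2 to compound 4 (beyond the scatter) in this assay, and sec-butyl in place of methyl gives a number 12 percentage points lower from compound 1 to compound 4 (beyond the scatter) in the same assay, so compound 4 goes against the earlier reading that a larger alkyl on the oxygen raises the number. The read-out therefore depends on which alkyl group sits on the oxygen, and the two butyl isomers lie far apart, with tert-butyl alone reaching the top of the series.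

Still open, on these data alone, is where unbranched n-butoxy, isopropoxy or ethoxy would fall relative to these compounds, and what an amine on the same carbonyl carbon, giving an amide, would do. Nothing shown here accounts for the gap between the sec-butyl and tert-butyl groups.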